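A few compounds are considered here, and "the series" means these few. Any claim that something is new, unique, unknown or untested is made for them only; others in the source may bear on it.

Three compounds of this series carry numbers in a functional assay on NCI-H460 cells (Homo sapiens) for cytotoxicity, read by MTT assay, with a stated time of 72 h; a higher number here means a weaker inhibitor, a lower number a stronger inhibitor. Compound 1, `CN(C)CCn1cnnc1-c1cc(Oc2ccc(NC(=O)N/N=C/c3ccc(Cl)cc3Cl)cc2F)ccn1`, gives 130 nM. Compound 2, `CN(C)CCn1cnnc1-c1cc(Oc2ccc(NC(=O)N/N=C/c3ccccc3)cc2F)ccn1`, gives 1780 nM. Compound 3, `CN(C)CCn1cnnc1-c1cc(Oc2ccc(NC(=O)N/N=C/c3cc(Br)c(O)c(Br)c3)cc2F)ccn1`, gives 3760 nM. Compound 2 therefore stands second highest of the three: its nearest neighbour is compound 3, with a 2.1-fold higher number from compound 2 to compound 3 (0.32 log units; beyond the scatter), and its furthest is compound 1, with a 14-fold higher number from compound 1 to compound 2 (1.14 log units; beyond the scatter).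

Compound 4, `CN(C)CCn1cnnc1-c1cc(Oc2ccc(NC(=O)N/N=C/c3ccc(F)cc3Cl)cc2F)ccn1`, has no number yet in this assay. It differs from compound 2 in one place: 2-chloro-4-fluorophenyl in place of phenyl on a carbon with a double bond to nitrogen. For the measured compounds named here, the step that bears on this change is the one between compound 1 and compound 2, a 14-fold higher number from compound 1 to compound 2 (1.14 log units; beyond the scatter), where a dihalogenated phenyl on that carbon goes with a much lower number than the plain phenyl. The 2-chloro-4-fluorophenyl of compound 4 is again a dihalogenated phenyl, though not the same one as in compound 1, so a large downward step from compound 2 is expected, likely not quite the full size of the step to compound 1. Compound 4 is thus expected to show a 5.9-fold lower number from compound 2 to compound 4 (0.77 log units; beyond the scatter) in this assay. For compound 4 the estimated value is 300 nM, within a range of 110 nM to 850 nM.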

Compound 4, half-maximal inhibitory concentration: 720 nM
Compound 4: the middle estimate sits 2.4-fold (0.38 log units) below what was measured; the measured number falls inside the stated range.
By their numbers in this assay, from the lowest: compound 1; then compound 4; then compound 2; then compound 3.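

In this assay, the lower number that went with a dihalogenated phenyl on the carbon with a double bond to nitrogen in compound 1 is no longer a single case, since 2-chloro-4-fluorophenyl gives a 2.5-fold lower number from compound 2 to compound 4 (0.39 log units; beyond the scatter) and, against the halogenated but hydroxylated ring of compound 3, a 5.2-fold lower number from compound 3 to compound 4 (0.72 log units; beyond the scatter) in this series, while compound 3 itself goes against any simple link between ring halogens and a lower number. With one chloro held in place, the exchange of the other halogen alone gives a 5.5-fold higher number from compound 1 to compound 4 (0.74 log units; beyond the scatter). This exchange accounts for a sizeable part of the distance from compound 2 to compound 1, which means that the identity of a single halogen on this ring matters and that the step from plain phenyl is not set by the presence of two halogens alone. Nothing at hand says why these numbers differ.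

Open, on these data alone, is how much each halogen contributes by itself, which a phenyl carrying a single chloro, at either of the places it holds in compound 1, would separate. Also open, as far as these compounds go, is whether the trend extends beyond halogens, for instance to a methoxy or a trifluoromethyl group on this ring.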